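The source may hold more compounds than are shown below. What is called first, only, known or untested is meant among the compounds shown, and "the series" means these compounds.

Measured compounds:
- Compound 1, `CC(c1ccc(-c2ccccc2)c(F)c1)c1nnc2n1N=C(c1ccc(OC(F)(F)F)cc1)CS2`: 4800 nM
- Compound 2, `COc1ccc2cc(C(C)c3nnc4n3N=C(c3ccc(Cl)cc3Cl)CS4)ccc2c1`: 14600 nM

Of the compounds shown here, two have been measured in a functional assay on MCF7 cells (Homo sapiens) for inhibition, read by sulforhodamine B assay, with a stated time of 72 h; a lower number here means a stronger inhibitor, a higher number a weaker inhibitor. Compound 1 gives 4800 nM, the lowest of the two numbers. Compound 2 gives 14600 nM, a higher number that lies beyond the scatter, so compound 1 is the stronger of the pair. The two differ in more than one place, so no single structural change can be read from that gap.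

Compound 3, `CC(c1ccc(-c2ccccc2)c(F)c1)c1nnc2n1N=C(c1ccccc1)CS2`, has not yet been measured. It differs from compound 1 in one place: hydrogen in place of trifluoromethoxy on an aromatic carbon. Going by the values given here, no measured pair shows this change, so its effect can only be guessed. A modest weakening is expected, with the step from compound 1 to compound 3 in this assay estimated at a 1.6-fold higher number from compound 1 to compound 3 (0.19 log units; within the scatter), within the usual scatter. Compound 3 is therefore expected to give about 7500 nM, with a likely range from 3000 nM to 20000 nM.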

Compound 3, half-maximal inhibitory concentration: 7400 nM
The estimate for compound 3 lay 1.0-fold (0.01 log units) above the measured number; measured number inside the range.
By their numbers in this assay, from the lowest: compounds 1, 3 and 2 (each within the scatter of the next, the first and the last beyond it).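

Replacing trifluoromethoxy with hydrogen on the aromatic ring gives, in this assay, a 1.5-fold higher number from compound 1 to compound 3 (0.19 log units; within the scatter). Going by these compounds alone, this is the first one-place comparison, and it shows that a 4-(trifluoromethoxy)phenyl group and a plain phenyl group cannot be told apart in this assay, even though the change removes every heavy atom of the substituent. So, in this pair, the trifluoromethoxy group is not needed for the activity seen, and no other measurement shown helps to explain this result.

On these data alone, with only hydrogen and trifluoromethoxy to compare at this place, it remains open whether an amine, a carboxylic acid or a longer alkyl chain there would leave the number unchanged or move it. The compounds shown also leave open what the fluorine elsewhere in compound 3 contributes.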